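The source may report more compounds than this note shows. Statements on the series, on what has been measured and on what is new or still open speak of the compounds shown alone.

Compound 1 `O=C(NCc1ccc(F)cc1)c1nc(Br)c2cccnc2c1NCc1ccccc1` carries a benzylamino group on the shared core, with a bromine on the ring and an amide to a fluorobenzyl group. In a functional assay on MDA-MB-435 cells (Homo sapiens) for cytotoxicity, read by MTT assay, with a stated time of 72 h (on this read-out higher numbers stand for weaker inhibition and lower numbers for stronger inhibition), compound 1 gives only a limit, > 20000 nM, and no number. The two other compounds tested alongside it fare no better on this read-out. Compound 2 `CS(=O)(=O)NCCCN(c1nc(C(=O)NCc2ccc(F)cc2)c(O)c2ncccc12)S(C)(=O)=O` gives a limit as well, > 20000 nM in this assay. Compound 3 `COC(=O)c1nc(Br)c2cccnc2c1N[C@H]1CC[C@H](N)CC1` likewise gives only a limit, > 20000 nM in this assay. Among the compounds with values here, compound 1 therefore stands at the limit of > 20000 nM in this assay, at which 3 of the 3 values shown sit, and no step between measured compounds can be drawn from these values, since none of them is a number.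

Compound 4 `CNCCCNc1c(C(=O)NCc2ccc(F)cc2)nc(Br)c2cccnc12` differs from compound 1 in one place (2-(methylamino)ethyl in place of phenyl on a saturated chain carbon bound to a nitrogen on an aromatic ring). Cut one bond further out, the benzylamino becomes a (3-(methylamino)propyl)amino.

Within the data shown here, with every measured value sitting at the limit, there is no measured step from which a direction for this change could be read. Compound 4 is expected to stay at the same limit, so the step that the limit leaves unreadable from compound 1 to compound 4 is expected to be none beyond the scatter. The estimate for compound 4 in this assay is 25000 nM, within 8000 nM to 80000 nM.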

Compound 4, half-maximal inhibitory concentration: 11000 nM
Compound 4: middle estimate off by 2.3-fold (0.36 log units), on the high side; low and high end bracket the measured number.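

Within the data shown here, at this position the earlier compounds offered only limits. Compound 4 is the first of those shown to give a number, 11000 nM, in this assay. With 2-(methylamino)ethyl in place of phenyl on a saturated chain carbon bound to a nitrogen on an aromatic ring, the record reads an at least 1.8-fold lower number from compound 1 to compound 4 (0.25 log units; that floor lies within the scatter), so the size of the step can only be given as a floor. The change from a benzylamino to a (3-(methylamino)propyl)amino is thus compatible with a measurable value, although this floor alone does not establish a step beyond the scatter.

As far as these compounds go, whether a shorter or longer chain, a primary amine or a dimethylamino group at the chain end, or an oxygen in place of the chain nitrogen would shift the number further remains open, as does how the same change would read on a core without the bromine. The true size of the step from the benzylamino stays unknown because compound 1 gives no number, and the same holds for most of the values shown: the limit of > 20000 nM in this assay, at which 3 of the 4 values shown sit.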